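The compounds below may be only part of what the source reports. "The series", "measured", "known", "first", "only" and "open" are said of these compounds alone.

Measured compounds:
compound 1, `CC1=C(C(=O)OCc2cccnc2)C(c2ccccc2[N+](=O)[O-])C2=C(CCCC2=O)N1`: 1.51
compound 2, `CC1=C(C(=O)OCc2ccccn2)C(c2ccc(Cl)cc2)C2=C(CCCC2=O)N1`: 2.24

Among the compounds with values here, in a physicochemical assay for lipophilicity, measured as octanol-water partition (a lower number here means a more polar compound, a higher number a more lipophilic compound), compound 1 gives 1.51, the lower of the two numbers so far. Compound 2 gives 2.24 in this assay, a value beyond the scatter above that of compound 1; the two compounds differ in more than one place, so the gap cannot be tied to a single change.

Compound 3, `CC1=C(C(=O)OCc2cccnc2)C(c2ccccc2)C2=C(CCCC2=O)N1`, has not yet been measured in this assay. It follows compound 1 by one change: hydrogen in place of nitro on an aromatic carbon. Within the data shown here, no step between measured compounds covers this change. The expectation is a small rise, at or just beyond the scatter, rather than a large one. Compound 3 is expected near 1.8, with a range from 1.4 to 2.2. The step of a number 0.29 log units higher from compound 1 to compound 3 (within the scatter) is the expected shift.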

Compound 3, partition coefficient: 2.35
The estimate for compound 3 lay 0.55 log units below the measured number, outside the stated range (above it).
By their numbers in this assay, from the lowest: compound 1; then compounds 2 and 3 (each within the scatter of the next).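

In this assay, hydrogen in place of nitro on an aromatic carbon, ortho to a large group, comes with a number 0.84 log units higher from compound 1 to compound 3 (beyond the scatter). Within the data shown here, this is the first gap that can be tied to one place, the 2-nitrophenyl to phenyl change, with the rest of the core of compound 1 held constant, and it shows that this position can move the read-out beyond the scatter. No measurement at hand bears on what lies behind the step.

From the compounds shown here alone, only nitro and hydrogen are compared at this place, so it remains open where an amine, a methoxy group or a carboxylic acid would fall relative to compound 1 and compound 3. Going by these compounds, it is also open whether the same change elsewhere on the aromatic ring would give a step of similar size.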